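Chloro to Methylsulfonyl on an Ester Without Cytotoxicity

The compounds below may be only part of what the source reports. "The series", "measured", "known", "first", "only" and "open" are said of these compounds alone.

Of the compounds shown here, three have been tested in an ADME assay on Raji cells (Homo sapiens) for cytotoxicity, read by CellTiter-Glo and resazurin assay, with a stated time of 72 h; on this read-out higher numbers stand for an effect only at larger amounts of compound and lower numbers for an effect already at smaller amounts. Compound 1 `CC(C)N(Cc1cccc(OCCCCCC(=O)O)c1)C(=O)c1ccc(-c2cccc(Cl)c2)cc1` carries a chloro group and a free carboxylic acid. In this assay compound 1 reaches only the limit > 21900 nM, a limit of the assay rather than a number. Compound 2 `CC(C)N(Cc1cccc(OCCCCCC(=O)O)c1)C(=O)c1ccc(-c2cccc(S(C)(=O)=O)c2)cc1` differs from compound 1 in that (methylsulfonyl in place of chloro on an aromatic carbon); in this assay compound 2 gives the limit > 26000 nM, again a limit and not a number. Compound 3 `CCOC(=O)CCCCCOc1cccc(CN(C(=O)c2ccc(-c3cccc(Cl)c3)cc2)C(C)C)c1` differs from compound 1 in that (ethyl in place of hydrogen on an oxygen next to a carbonyl group), and in this assay compound 3 gives the limit > 18400 nM, once more a limit. The two measured steps, a step that the two limits leave unreadable from compound 1 to compound 2 and a step that the two limits leave unreadable from compound 1 to compound 3, cannot be sized, since every value sits at a limit, as seen in the limit of > 18400 nM in this assay, at which 1 of the 3 values shown sits, the limit of > 21900 nM in this assay, at which 1 of the 3 values shown sits, and (the limit of > 26000 nM in this assay, at which 1 of the 3 values shown sits).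

Compound 4 `CCOC(=O)CCCCCOc1cccc(CN(C(=O)c2ccc(-c3cccc(S(C)(=O)=O)c3)cc2)C(C)C)c1` is not yet measured. It differs from compound 3 in that (methylsulfonyl in place of chloro on an aromatic carbon), which is the same change made from compound 1 to compound 2, at the same place. The cores of compound 1 and compound 3 differ in that (ethyl in place of hydrogen on an oxygen next to a carbonyl group). For compound 4 the step that the limit leaves unreadable from compound 3 to compound 4 is expected to be small, resting on the fact that the same change left compound 2 at a limit of > 26000 nM in this assay, at which 1 of the 3 values shown sits, just as compound 1 sat at one (the limit of > 21900 nM in this assay, at which 1 of the 3 values shown sits). Compound 4 is therefore estimated at 25000 nM, in a range from 12000 nM to 60000 nM, most likely again reported only as a limit.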

Compound 4, half-maximal effective concentration: > 26000 nM
Compound 4 was reported as a limit; the forecaster's own chance of this, stated with the estimate: 85%; at least 1.0-fold (0.01 log units) between middle value and limit.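

In this assay compound 4 gives > 26000 nM as a limit and not a number. No new step can be read, neither from compound 3 to compound 4 nor from compound 2 to compound 4, since each of these compounds sits at a limit, the highest of them shared by two compounds: the limit of > 26000 nM in this assay, at which 2 of the 4 values shown sit.

The compounds shown leave open at what concentration any of them would affect these cells, and whether either change alters that concentration at all.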